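The compounds below may be only part of what the source reports. "The series", "measured", "known", "first", "only" and "open" are said of these compounds alone.

Working notes on the series. In a functional assay on CHO cells with adenosine receptor A1 (Homo sapiens) as the target, read by cAMP accumulation and immunoassay, with a stated time of 6 min, tested at 0.01 uM (on this read-out lower numbers stand for a stronger effect and higher numbers for a weaker effect at the one concentration tested), compound 1 `Nc1scc(CN2CCN(c3ccc(Cl)cc3Cl)CC2)c1C(=O)c1ccc(Cl)cc1` gives 2% and compound 2 `Nc1scc(CN2CCN(c3ccc(F)c(F)c3)CC2)c1C(=O)c1ccc(Cl)cc1` gives -3.2%; the values of compound 2 and compound 1 lie within the scatter of each other, so no order can be drawn between them. For the measured compounds named here, the only measured step, a number 5.2 percentage points lower from compound 1 to compound 2 (within the scatter), is a change of the aryl group on the same ring nitrogen and moved nothing beyond the scatter. Compound 3 `Nc1scc(CN2CCN(c3cc(F)ccc3F)CC2)c1C(=O)c1ccc(Cl)cc1` differs from compound 2 by 2,5-difluorophenyl in place of 3,4-difluorophenyl on an amine nitrogen in a ring. Going by the values given here, no measured pair shows this exact change; the one related step suggests no step beyond the scatter is expected, a number 2.2 percentage points higher from compound 2 to compound 3 (within the scatter). Compound 3 is therefore estimated at -1%, between -12% and 10%.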

Compound 3, a percentage reported as activity, at one concentration (the size of the read-out at that concentration, not a potency): 3.1%
Beside the measured number, compound 3's estimate is 4.1 percentage points below it; the range from low to high includes it.
By their numbers in this assay, from the lowest: compounds 2, 1 and 3 (each within the scatter of the next).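

At this place, 2,5-difluorophenyl in place of 3,4-difluorophenyl gives a number 6.3 percentage points higher from compound 2 to compound 3 (within the scatter), so in this assay rearranging the two fluorines on the aryl ring does not separate the compounds. The same group in place of 2,4-dichlorophenyl gives a number 1.1 percentage points higher from compound 1 to compound 3 (within the scatter), so the three aryl patterns shown cannot be ordered. No available evidence bears on these results.

On these data alone, whether an unsubstituted phenyl or a methoxyphenyl group on the same ring nitrogen would give a step beyond the scatter remains open.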